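A few compounds are considered here, and "the series" means these few. Any claim that something is new, unique, unknown or untested is made for them only; others in the source may bear on it.

In a functional assay on K562 cells (Homo sapiens) for antiproliferative activity, read by MTT assay, with a stated time of 48 h (on this read-out lower numbers stand for stronger inhibition and higher numbers for weaker inhibition), compound 3 `CN1CCN(CCCn2c(N)c(-c3nc4ccccc4[nH]3)c3nc(C#N)c(C#N)nc32)CC1` gives 1260 nM and stands level, within the scatter, with compound 1 `CCN(CC)CCn1c(N)c(-c2nc3ccccc3[nH]2)c2nc(C#N)c(C#N)nc21` at 2490 nM. Compound 2 `CCCn1c(N)c(-c2nc3ccccc3[nH]2)c2nc(C#N)c(C#N)nc21` gives > 50000 nM, which is a limit of the assay and not a number.

Compound 4 `CCCCn1c(N)c(-c2nc3ccccc3[nH]2)c2nc(C#N)c(C#N)nc21` is still unmeasured. Its difference from compound 3 is methyl in place of 4-methylpiperazin-1-yl on a saturated chain carbon, three bonds along the chain from an aromatic nitrogen, so that 3-(4-methylpiperazin-1-yl)propyl becomes butyl.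

The closest measured step is an at least 39-fold lower number from compound 2 to compound 3 (1.59 log units; beyond the scatter), which involves the same group on the chain. The step of an at least 20-fold higher number from compound 1 to compound 2 (1.30 log units; beyond the scatter) points the same way for the loss of diethylamino. Exchanging one of these groups for the other, as in a 2.0-fold lower number from compound 1 to compound 3 (0.30 log units; within the scatter), stays within the scatter. Among these three compounds, the plain alkyl chain goes with the weak end of the range, and none goes against this.

A large rise in the number is therefore expected in this assay, not a change within the scatter. The expected size is a 32-fold higher number from compound 3 to compound 4 (1.50 log units; beyond the scatter) as an estimate. For compound 4 the expected value is 40000 nM with an estimated range from 12000 nM to 120000 nM and a fair chance of a report as a limit.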

Compound 4, half-maximal inhibitory concentration: > 50000 nM
Compound 4 gave a limit, no number; the forecaster's own chance of this, stated with the estimate: 65%; at least 1.2-fold (0.09 log units) between middle value and limit.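

In this assay compound 4 gives > 50000 nM, which is a limit of the assay and not a number. Exchanging 3-(4-methylpiperazin-1-yl)propyl for butyl gives an at least 39-fold higher number from compound 3 to compound 4 (1.59 log units; beyond the scatter), and the change from the diethylamino chain to the butyl chain gives an at least 20-fold higher number from compound 1 to compound 4 (1.30 log units; beyond the scatter), so the loss seen with the propyl chain now recurs with a second plain alkyl chain, and neither plain chain goes against it. The effect of going from propyl to butyl cannot be read, because both plain chains sit at the same limit, and any difference between them stays hidden: the limit of > 50000 nM in this assay, at which 2 of the 4 values shown sit.

Open, going by these compounds, is whether a group other than diethylamino and 4-methylpiperazin-1-yl on the chain, such as a hydroxyl group or a morpholine ring, would keep a readable value in this assay. Also open, on these data alone, is how chain length acts with the amine held fixed, for instance diethylamino on a propyl chain, and whether a shorter or longer plain alkyl chain would give a number rather than a limit.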